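The source may report more compounds than this note shows. Statements on the series, on what has been measured and on what is new or still open speak of the compounds shown alone.

Compound 1, `N#Cc1cnc(NCc2cnccc2C(F)(F)F)cc1N[C@H]1CC[C@@H](C(N)=O)CC1`, gives 7 nM in an assay on isolated protein for inhibition of protein kinase C theta type (Homo sapiens), read by TR-FRET, with a stated time of 2 h; a higher number here means a weaker inhibitor, a lower number a stronger inhibitor.
Compound 2, `CN(C)C(=O)[C@H]1CC[C@@H](Nc2cc(NCc3cnccc3C(F)(F)F)ncc2C#N)CC1`, gives 38 nM in this assay.

For the measured compounds named here, of the two measured compounds, compound 2 has the higher number, and the only measured step that separates them, a 5.4-fold higher number from compound 1 to compound 2 (0.73 log units; beyond the scatter), lies beyond the scatter. Compound 3, `N#Cc1cnc(NCc2cnccc2C(F)(F)F)cc1N[C@H]1CC[C@@H](c2nc[nH]n2)CC1`, is the next compound in this account. It differs from compound 2 in one place: 1H-1,2,4-triazol-3-yl in place of dimethylcarbamoyl on a saturated ring carbon. Going by the values given here, the one measured step that bears on this position is the one already given, from compound 1 to compound 2, where an amino group on the carbonyl carbon was replaced by dimethylamino and the number rose modestly. Compound 3 moves the other way in the sense that a hydrogen-bond donor returns to this position, though as part of an aromatic ring rather than an amide. The expectation is therefore a step back toward the number of compound 1, estimated as a 3.2-fold lower number from compound 2 to compound 3 (0.50 log units; beyond the scatter). Compound 3 is expected to give about 12 nM in this assay, within a range of 4 nM to 40 nM.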

Compound 3, half-maximal inhibitory concentration: 34 nM
Compound 3: middle estimate off by 2.8-fold (0.45 log units), on the low side; the measured number falls inside the stated range.
By their numbers in this assay, from the lowest: compound 1; then compounds 3 and 2 (each within the scatter of the next).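

In this assay, 1H-1,2,4-triazol-3-yl in place of dimethylcarbamoyl on the saturated ring carbon gives a 1.1-fold lower number from compound 2 to compound 3 (0.05 log units; within the scatter), so these two groups, each of 5 heavy atoms, cannot be told apart here, although only the entering ring has a hydrogen-bond donor. Against the carbamoyl group of compound 1, the same ring gives a 4.9-fold higher number from compound 1 to compound 3 (0.69 log units; beyond the scatter), a modest step, which shows that a hydrogen-bond donor in a group at this position does not by itself bring the number back to that of compound 1, and that among the three groups shown only carbamoyl reaches that level. No measurement offered here speaks to the reason for these results.

The compounds shown leave open how a carboxylic acid or a primary amine on this ring carbon would compare with carbamoyl, and whether an amide with a single methyl group on its nitrogen would stay close to compound 1 or fall in with compound 2. They also leave open whether a methyl group on the triazole ring, or another five-membered aromatic ring such as a tetrazole, would change the number at all.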